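Swapping a nitrile for fluorine on the benzyl ether

The compounds below may be only part of what the source reports. "The series", "measured", "known", "first", "only" and "open" are said of these compounds alone.

Of the compounds shown here, three sharing one core have been measured in a functional assay on Huh-7 cells (Homo sapiens) for antiproliferative activity, read by sulforhodamine B assay, with a stated time of 72 h; a lower number here means a stronger inhibitor, a higher number a weaker inhibitor. Compound 1 `Cc1cc(C)cc(COc2ccc(-c3cc(CN4CCN(Cc5ccc(C(F)(F)F)cc5)CC4)no3)cc2)c1` gives 600 nM. Compound 2 `FC(F)(F)c1ccc(CN2CCN(Cc3cc(-c4ccc(OCc5cccc(Cl)c5)cc4)on3)CC2)cc1` gives 200 nM, and compound 3 `N#Cc1cccc(COc2ccc(-c3cc(CN4CCN(Cc5ccc(C(F)(F)F)cc5)CC4)no3)cc2)c1` gives 100 nM. Compound 3 carries the lowest number of the three: it sits a 2.0-fold lower number from compound 2 to compound 3 (0.30 log units; within the scatter) from compound 2, a gap that stays within the scatter, and a 6.0-fold lower number from compound 1 to compound 3 (0.78 log units; beyond the scatter) from compound 1, which is beyond it. The step of a 3.0-fold lower number from compound 1 to compound 2 (0.48 log units; beyond the scatter) shows that replacing the 3,5-dimethylphenyl of compound 1 by a single small ring substituent already brought the number down.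

Compound 4 `Fc1cccc(COc2ccc(-c3cc(CN4CCN(Cc5ccc(C(F)(F)F)cc5)CC4)no3)cc2)c1` has not yet been measured. It differs from compound 3 in one place: fluoro in place of cyano on an aromatic carbon. The closest guide is the step of a 2.0-fold lower number from compound 2 to compound 3 (0.30 log units; within the scatter), where one small substituent at the same ring position gave way to another and the number moved only within the scatter. Fluoro, like chloro, is a single halogen atom, so a number close to that of compound 2 or compound 3 is the natural expectation, with no step beyond the scatter firmly predicted. The estimate for compound 4 in this assay is therefore 200 nM, with a range from 80 nM to 500 nM, meaning an expected step of a 2.0-fold higher number from compound 3 to compound 4 (0.30 log units; within the scatter).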

Compound 4, half-maximal inhibitory concentration: 1300 nM
The estimate for compound 4 lay 6.5-fold (0.81 log units) below the measured number; the whole stated range lies below it.
By their numbers in this assay, from the lowest: compounds 3 and 2 (each within the scatter of the next); then compound 1; then compound 4.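

At this ring position, a single small substituent cannot be swapped freely: in this assay the change from nitrile to fluoro gives a 13-fold higher number from compound 3 to compound 4 (1.11 log units; beyond the scatter) and the change from chloro to fluoro gives a 6.5-fold higher number from compound 2 to compound 4 (0.81 log units; beyond the scatter) even though chloro and cyano themselves stay within the scatter of each other. Compound 1 also shows that a lone substituent does not always improve on the 3,5-dimethylphenyl group: putting 3-fluorophenyl in its place gives a 2.2-fold higher number from compound 1 to compound 4 (0.34 log units; beyond the scatter) and so reverses the direction seen with chloro and cyano, leaving compound 4 as the exception among the single-substituent compounds. No measurement is available that bears on why fluoro stands apart from the other two groups.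

The compounds shown leave open how a ring with only hydrogen at this position would compare, and whether bromo, methoxy or a carboxylic acid would fall with chloro and cyano or nearer to fluoro. They also leave open whether fluoro would give a similar number at another position on the same ring.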